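Propyl at the benzimidazole position: expectation for compound 4

A few compounds are considered here, and "the series" means these few. Any claim that something is new, unique, unknown or untested is made for them only; others in the source may bear on it.

Three compounds share one core and differ only in the group on an aromatic carbon of the fused five-membered ring. Compound 1 `CCCCOC(=O)NS(=O)(=O)c1ccc(CCC)cc1-c1ccc(Cn2c(C(C)C)nc3ccccc32)cc1` carries isopropyl there and gives 4 nM in an assay on membranes from HEK293 cells for displacement of a labelled ligand from Type-2 angiotensin II receptor (Homo sapiens), read by radioligand binding; a higher number here means a weaker inhibitor, a lower number a stronger inhibitor. Compound 2 `CCCCOC(=O)NS(=O)(=O)c1ccc(CCC)cc1-c1ccc(Cn2c(-c3nccs3)nc3ccccc32)cc1` carries 1,3-thiazol-2-yl and gives 5.1 nM in this assay; it stands second highest of the three numbers, with compound 1 nearest and compound 3 furthest. Compound 3 `CCCCOC(=O)NS(=O)(=O)c1ccc(CCC)cc1-c1ccc(Cn2c(Cc3ccccc3)nc3ccccc32)cc1` carries benzyl and gives 15 nM in this assay.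

The measured steps: a 1.3-fold higher number from compound 1 to compound 2 (0.11 log units; within the scatter), a 3.8-fold higher number from compound 1 to compound 3 (0.57 log units; beyond the scatter), a 2.9-fold higher number from compound 2 to compound 3 (0.47 log units; beyond the scatter). Only the benzyl replacements move the number beyond the scatter, and then modestly.

Compound 4 `CCCCOC(=O)NS(=O)(=O)c1ccc(CCC)cc1-c1ccc(Cn2c(CCC)nc3ccccc32)cc1` is not yet measured. propyl in place of 1,3-thiazol-2-yl on an aromatic carbon The step from compound 1 to compound 2 bears most directly on it, since it shows a small alkyl and the aromatic 1,3-thiazol-2-yl within the scatter of each other; propyl is another small chain, so no step beyond the scatter is expected in this assay, with the benzyl steps marking the only direction in which a change has been seen. Compound 4 is therefore expected at 5 nM, within 2.5 nM to 10 nM. The expected step is a 1.0-fold lower number from compound 2 to compound 4 (0.01 log units; within the scatter).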

Compound 4, inhibition constant: 14 nM
Compound 4: middle estimate off by 2.8-fold (0.45 log units), on the low side, and the stated range ends below it.
By their numbers in this assay, from the lowest: compounds 1 and 2 (each within the scatter of the next); then compounds 4 and 3 (each within the scatter of the next).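

In this assay, the change from isopropyl to propyl is not silent (a 3.5-fold higher number from compound 1 to compound 4 (0.54 log units; beyond the scatter)), so these two alkyl groups are not interchangeable on this aromatic carbon between two ring nitrogen atoms, and the earlier closeness of a small alkyl and an aromatic ring rests only on isopropyl and 1,3-thiazol-2-yl. Propyl also separates from 1,3-thiazol-2-yl (a 2.7-fold higher number from compound 2 to compound 4 (0.44 log units; beyond the scatter)) but not from benzyl (a 1.1-fold lower number from compound 3 to compound 4 (0.03 log units; within the scatter)), so the four compounds form two pairs, compounds 1 and 2 against compounds 3 and 4, and benzyl no longer marks the only direction of change. Nothing available accounts for this split, and the shared feature of the propyl and benzyl compounds stays unexplained.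

Whether the branch in isopropyl is what sets compound 1 apart from compound 4 stays open, since tert-butyl, cyclopropyl and ethyl are absent from the compounds shown. From the compounds shown here alone, it is equally open whether a longer chain such as butyl, or a chain ending in an amine or a carboxylic acid, would fall with the propyl and benzyl pair or apart from it.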